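This account rests on a few compounds, and the source may have more. Where it says the series, first, only, none or still open, it means among the compounds named here.

The three measured compounds share one core and differ only in the group on the double-bonded nitrogen. Compound 1 `C/C(=N\C(C)C)c1c(O)c2ccccc2[nH]c1=O` carries an isopropyl group there. In an assay on isolated protein for inhibition of myosin-2 (Bos taurus), read by spectrophotometry, with a stated time of 24 min (on this read-out higher numbers stand for weaker inhibition and lower numbers for stronger inhibition), compound 1 gives only a limit of the assay, >= 100000 nM. Compound 2 `C/C(=N\CC1CCCCC1)c1c(O)c2ccccc2[nH]c1=O` carries a cyclohexylmethyl group. In this assay compound 2 likewise gives only a limit, >= 100000 nM. Compound 3 `CCCC/N=C(\C)c1c(O)c2ccccc2[nH]c1=O` carries a butyl group. In this assay compound 3 also gives only a limit, >= 100000 nM. Because all three values sit at the limit of >= 100000 nM in this assay, at which 3 of the 3 values shown sit, the steps between them cannot be read: a step that the two limits leave unreadable from compound 1 to compound 2, a step that the two limits leave unreadable from compound 1 to compound 3 and a step that the two limits leave unreadable from compound 2 to compound 3 are each of unreadable size. Compound 3 thus stands at the limit of the assay, as do the other two.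

Compound 4 `CCCCC/N=C(\C)c1c(O)c2ccccc2[nH]c1=O` differs from compound 3 by methyl in place of hydrogen on a saturated chain carbon, four bonds along the chain from a double-bonded nitrogen. Among the measured compounds shown here, none of the measured steps can be read, so they give no readable size for this change in this assay; the expectation rests only on the fact that every measured compound sits at the limit. Compound 4 is therefore expected to sit at the limit as well, a step of a number no higher from compound 3 to compound 4 (the limit leaves the size open). Compound 4 is estimated at 100000 nM, within a range of 30000 nM to 300000 nM.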

Compound 4, half-maximal inhibitory concentration: >= 100000 nM
Compound 4: no number, only a limit (the forecaster's own chance of this, stated with the estimate: 85%); the middle value lies on the limit itself.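

In this assay compound 4 gives >= 100000 nM as a limit, not a number. Among the compounds shown here, no step from compound 1, compound 2 or compound 3 to compound 4 can be read, since all four sit at one limit: the limit of >= 100000 nM in this assay, at which 4 of the 4 values shown sit. The compounds shown leave open whether any group on the double-bonded nitrogen of the shared core gives a readable inhibition.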